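Pyridin-4-yl in Place of 4-Chlorophenyl: Expected Solubility

The source may report more compounds than this note shows. Statements on the series, on what has been measured and on what is new or still open speak of the compounds shown alone.

Of the compounds shown here, two of a shared core have been measured in a physicochemical assay for solubility, read by nephelometry, in phosphate buffer, measured as kinetic solubility, at pH 6.5; on this read-out lower numbers stand for lower solubility and higher numbers for higher solubility. Compound 1 `CCOC(=O)C1=C(C)N/C(=C/c2cc(C)n(-c3ccc(Cl)cc3)c2C)C1=O` gives 1.6 ug/mL in this assay. Compound 2 `CCOC(=O)C1=C(C)N/C(=C/c2cc(C)n(-c3cc(OC)c(OC)c(OO)c3)c2C)C1=O` gives 3.1 ug/mL in this assay, and the two numbers lie within the usual scatter of each other, so compound 1 stands alongside compound 2 rather than apart from it. Compound 3 `CCOC(=O)C1=C(C)N/C(=C/c2cc(C)n(-c3ccncc3)c2C)C1=O` has not yet been measured. It differs from compound 1 in one place: pyridin-4-yl in place of 4-chlorophenyl on an aromatic nitrogen. Within the data shown here, no pair of measured compounds shows a step of this kind, so the size of the step in this assay is not known from measurement. The author expects a moderate rise in this assay, a 3.8-fold higher number from compound 1 to compound 3 (0.57 log units; beyond the scatter), rather than a step hidden in the scatter. For compound 3 the estimate in this assay is 6 ug/mL, with a range from 2 ug/mL to 20 ug/mL.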

Compound 3, solubility: 50 ug/mL
Compound 3: middle estimate off by 8.3-fold (0.92 log units), on the low side; measured number above the stated range.
By their numbers in this assay, from the lowest: compounds 1 and 2 (each within the scatter of the next); then compound 3.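

In this assay, pyridin-4-yl in place of 4-chlorophenyl on the aromatic nitrogen gives a 31-fold higher number from compound 1 to compound 3 (1.49 log units; beyond the scatter), so the group at this position can move the number far. Compound 1 and compound 2 had stood within the scatter of each other, and that pair gave no sign of a change this large at this position. The data at hand offer nothing that explains the step.

The change swaps a carbon-only ring bearing chlorine for a ring with a hetero atom, and unsubstituted phenyl would be needed to separate those two parts of the step. As far as these compounds go, it also remains open whether pyridin-3-yl, or a phenyl ring bearing a carboxylic acid or a morpholine, would give a step of similar size in this assay.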